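The source may report more compounds than this note shows. Statements on the series, on what has been measured and on what is new or still open speak of the compounds shown alone.

Compound 1 `CCCCNc1ccnc2cc(Cl)ccc12` is the starting point of this step. In a functional assay on 184B5 cells (Homo sapiens) for cytotoxicity, read by sulforhodamine B assay, with a stated time of 48 h, in the presence of a further agent that is not named here (a higher number here means a weaker inhibitor of growth, a lower number a stronger inhibitor of growth), compound 1 gives > 20000 nM, which is a limit of the assay rather than a number, so its standing is known only as a bound; the limit of > 20000 nM in this assay, at which 1 of the 2 values shown sits, marks this. Compound 2 `CCCCNc1ccnc2cc(F)ccc12` gives 12500 nM in this assay, and the step of an at least 1.6-fold lower number from compound 1 to compound 2 (0.20 log units; that floor lies within the scatter) is the only measured one, a change of the halogen on the aromatic ring, not of the chain. Compound 3 `CN(C)CCNc1ccnc2cc(Cl)ccc12` differs from compound 1 by dimethylamino in place of ethyl on a saturated chain carbon, two bonds along the chain from a nitrogen on an aromatic ring. Among the measured compounds shown here, no measured step touches this chain position, so the expected size rests only on the bound for compound 1. For compound 3 a step of an at least 1.3-fold lower number from compound 1 to compound 3 (0.12 log units; that floor lies within the scatter) toward a lower number is expected, of a size not clearly beyond the scatter. Compound 3 is therefore estimated at 15000 nM, with a range from 4000 nM to 40000 nM.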

Compound 3, concentration for 50% growth inhibition: > 20000 nM
Compound 3 gave a limit, no number; the forecaster's own chance of this, stated with the estimate: 40%; middle value at least 1.3-fold (0.12 log units) away from the limit.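

In this assay, among the compounds shown here, compound 1 and compound 3 both stand at a limit, so no step between them can be read: the limit of > 20000 nM in this assay, at which 2 of the 3 values shown sit. The compounds shown leave open how far each lies from that limit, and whether dimethylamino in place of ethyl on this chain carbon changes growth inhibition at all.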